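Aryl sulfonyl enones: replacing the nitrothiophene arm

The source may report more compounds than this note shows. Statements on the series, on what has been measured and on what is new or still open speak of the compounds shown alone.

Compound 1 `O=C(/C(=C\c1csc([N+](=O)[O-])c1)S(=O)(=O)c1ccc(Br)cc1)c1ccc(Br)cc1` is the anchor of this comparison. In a functional assay on DU-145 cells (Homo sapiens) for inhibition, read by trypan blue exclusion, with a stated time of 96 h (a higher number here means a weaker inhibitor of growth, a lower number a stronger inhibitor of growth), compound 1 gives 1000 nM, level at the digits printed with compound 2 `O=C(O)c1ccc(C(=O)/C(=C\c2ccc(Br)cc2)SCc2ccc(Br)cc2)cc1`, which gives 1000 nM; together these are the lowest two of the three numbers. Compound 3 `Cc1ccsc1/C=C(\C(=O)c1ccc(Cl)cc1)S(=O)(=O)Cc1ccc(Cl)cc1` gives 25000 nM, well beyond the scatter above both. Compound 4 `O=C(/C(=C\c1ccc(F)cc1Cl)S(=O)(=O)c1ccc(Br)cc1)c1ccc(Br)cc1` differs from compound 1 in one place: 2-chloro-4-fluorophenyl in place of 5-nitrothiophen-3-yl on a double-bonded chain carbon bound to a double-bonded chain carbon. Within the data shown here, no measured pair isolates this change, so its size cannot be read from the data. The expected step is small, a 1.5-fold higher number from compound 1 to compound 4 (0.18 log units; within the scatter), if anything towards a slightly higher number. Compound 4 is therefore estimated at 1500 nM, with a range from 400 nM to 6000 nM.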

Compound 4, concentration for 50% growth inhibition: 50000 nM
Beside the measured number, compound 4's estimate is 33-fold (1.52 log units) below it, and the stated range ends below it.
By their numbers in this assay, from the lowest: compounds 1 and 2 (each within the scatter of the next); then compounds 3 and 4 (each within the scatter of the next).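

In this assay this position, on a double-bonded chain carbon bound to a double-bonded chain carbon, proves sensitive: 2-chloro-4-fluorophenyl in place of 5-nitrothiophen-3-yl gives a large step (a 50-fold higher number from compound 1 to compound 4 (1.70 log units; beyond the scatter)). Among these compounds, the earlier compounds offered no single-place comparison, so this one pair is the first direct reading. No measured evidence bears on the reason for this step.

Open, on these data alone, is whether the nitro group or the thiophene ring carries the difference: an amine on the thiophene ring, or a nitro group on a phenyl ring, would separate the two.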